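Methoxy on the Indole of a Series at the Limit

This account rests on a few compounds, and the source may have more. Where it says the series, first, only, none or still open, it means among the compounds named here.

Measured so far:
Compound 1 `CO[C@@H]1[C@H](N(C)c2ncc(-c3c[nH]c4ccccc34)s2)C[C@H]2O[C@]1(C)n1c3ccccc3c3c4c(c5c6cc(Cl)ccc6n2c5c31)C(=O)NC4` — in this assay, a limit: > 10000 nM
Compound 2 `CO[C@@H]1[C@H](N(C)c2ncc(-c3c[nH]c4ccccc34)s2)C[C@H]2O[C@]1(C)n1c3ccccc3c3c4c(c5c6cc(Br)ccc6n2c5c31)C(=O)NC4` — in this assay, a limit: > 10000 nM

In a functional assay on K562 cells (Homo sapiens) for antiproliferative activity, read by CellTiter-Glo, with a stated time of 72 h (on this read-out lower numbers stand for stronger inhibition and higher numbers for weaker inhibition), compound 1 reaches only the limit of > 10000 nM. Compound 2, with bromo in place of chloro on an aromatic carbon, gives > 10000 nM, again a limit. The step that the two limits leave unreadable from compound 1 to compound 2 cannot be read because both values sit at the limit of > 10000 nM in this assay, at which 2 of the 2 values shown sit. Within the data shown here, compound 2 therefore stands nowhere on the scale of numbers; it is known only to lie beyond the limit, as is the one further value shown.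

Compound 3 `COc1ccc2[nH]cc(-c3cnc(N(C)[C@@H]4C[C@H]5O[C@@](C)([C@@H]4OC)n4c6ccccc6c6c7c(c8c9cc(Br)ccc9n5c8c64)C(=O)NC7)s3)c2c1` differs from compound 2 by methoxy in place of hydrogen on an aromatic carbon. No measured step bears on a change of this kind: the only step shown, from chloro to bromo, is itself unreadable, so it gives no size and no direction to carry over. What can be said is that compound 2 itself sits at the limit, and the methoxy adds only 2 heavy atoms to a series in which neither measured compound gave a number.

Compound 3 is estimated at 12000 nM, with a range from 3000 nM to 50000 nM. The corresponding expected step is a step that the limit leaves unreadable from compound 2 to compound 3, most likely again ending at a limit rather than a number.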

Compound 3, half-maximal inhibitory concentration: > 10000 nM
Compound 3: a limit, no number; the forecaster's own chance of this, stated with the estimate: 80%; the middle value is on the limit's open side.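

In this assay compound 3 gives > 10000 nM, a limit and not a number. No step from compound 2 to compound 3 can be read, because both values sit at the same limit: the limit of > 10000 nM in this assay, at which 3 of the 3 values shown sit.

The compounds shown leave open how strongly any of them inhibits these cells, and whether bromo, chloro or methoxy changes that at all.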